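The compounds below may be only part of what the source reports. "The series", "measured", "known", "first", "only" and "open" are said of these compounds alone.

Three compounds sharing one core were compared in an ADME assay on J774.A1 cells (Mus musculus) for cytotoxicity; on this read-out lower numbers stand for higher toxicity in this test and higher numbers for lower toxicity in this test. Compound 1 `c1ccc2c(c1)ccn2-c1nc(N2CCNCC2)nc2ccccc12` gives 3.11 ug/mL in this assay. Compound 2 `CN1CCN(c2nc(-c3cn(C)c4ccccc34)c3ccccc3n2)CC1` gives 1.03 ug/mL, and compound 3 `COc1ccc(-c2nc(N3CCN(C)CC3)nc3ccccc23)c(OC)c1` gives 18 ug/mL. Among these three numbers compound 1 stands second highest: compound 2 sits at a lower number beyond the usual scatter, compound 3 at a higher number, also beyond the scatter. Compound 4 `c1ccc(N2CCN(c3nc(-n4ccc5ccccc54)c4ccccc4n3)CC2)nc1` differs from compound 1 in one place: pyridin-2-yl in place of hydrogen on an amine nitrogen in a ring. Among the measured compounds shown here, no pair of measured compounds isolates such a change, so the expectation rests on the spread of the three values alone. A small step toward a lower number, near the edge of the scatter, is expected a 1.6-fold lower number from compound 1 to compound 4 (0.19 log units; within the scatter). For compound 4 the estimated value is 2 ug/mL, within 0.7 ug/mL to 6 ug/mL.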

Compound 4, half-maximal cytotoxic concentration: 1.35 ug/mL
Estimate against measurement, compound 4: 1.5-fold (0.17 log units) above; the range from low to high includes it.
By their numbers in this assay, from the lowest: compounds 2 and 4 (each within the scatter of the next); then compound 1; then compound 3.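

In this assay, pyridin-2-yl on the amine nitrogen in the ring, where compound 1 carries hydrogen, gives a 2.3-fold lower number from compound 1 to compound 4 (0.36 log units; beyond the scatter). Among the compounds shown here, this is the first direct reading at this position, and it shows that this change moves the read-out modestly toward higher toxicity in this test. No measurement shown accounts for the step.

On these data alone, whether a plain phenyl would give a similar step, and so whether the ring nitrogen of pyridin-2-yl matters, remains open. So does the outcome with an acetyl group or a carboxylic acid on a short chain at this nitrogen.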